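The compounds below may be only part of what the source reports. "The series", "measured", "known", "first", "only" and "open" are said of these compounds alone.

Measured in an ADME assay on HEK293 cells (Homo sapiens) for cytotoxicity, read by MTT assay, with a stated time of 72 h; on this read-out higher numbers stand for weaker inhibition and lower numbers for stronger inhibition:
- Compound 1 `C=CCOc1cc(C2=C(c3cc(OC)c(OC)c(OC)c3)C(=O)C(O)C2)ccc1OC`: > 100 ug/mL
- Compound 2 `COc1ccc(C2=C(c3cc(OC)c(OC)c(OC)c3)C(=O)C(O)C2)cc1F`: > 100 ug/mL

In this assay, compound 2 gives > 100 ug/mL, which is a limit and not a number. Compound 1 gives > 100 ug/mL, which is also a limit. The evidence so far is therefore (the limit of > 100 ug/mL in this assay, at which 2 of the 2 values shown sit).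

Compound 3 `COc1ccc(C2=C(c3cc(OC)c(OC)c(OC)c3)C(=O)C(O)C2)cc1OC(C)C` differs from compound 2 in one place: isopropoxy in place of fluoro on an aromatic carbon. Isopropoxy stands in place of fluoro on an aromatic carbon, ortho to a methoxy group.

Among the compounds with values here, only one measured step bears on this change: a step that the two limits leave unreadable from compound 1 to compound 2. It swaps allyloxy for fluoro on an aromatic carbon, but it has no readable size, so it offers no measured size or direction to carry over. The expected change is therefore none beyond the scatter, and the estimated step is a step that the limit leaves unreadable from compound 2 to compound 3. Another limit is the most likely report. For compound 3 the estimated value is 150 ug/mL, with an expected range of 60 ug/mL to 400 ug/mL.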

Compound 3, half-maximal inhibitory concentration: > 100 ug/mL
Compound 3: only a limit was reported; the forecaster's own chance of this, stated with the estimate: 80%; the middle value does not contradict the limit.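

No step between compound 1, compound 2 and compound 3 can be read, since each result is a limit and not a number: the limit of > 100 ug/mL in this assay, at which 3 of the 3 values shown sit.

The compounds shown leave open how far apart they truly lie in this assay, and whether exchanging allyloxy, fluoro and isopropoxy changes the read-out at all.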